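Piperidine for Morpholine on a Thiocarbonyl Carbon

The source may hold more compounds than are shown below. What is called first, only, known or untested is meant among the compounds shown, and "the series" means these compounds.

Compound 1 `COc1ccc2oc(CSC(=S)N3CCOCC3)cc(=O)c2c1` and compound 3 `COc1ccc2oc(CSC(=S)N3CCCCC3)cc(=O)c2c1` share one core and differ in a single place: piperidin-1-yl in place of morpholin-4-yl on a thiocarbonyl carbon. In a functional assay on MDA-MB-435S cells (Homo sapiens) for antiproliferative activity, read by MTT assay, with a stated time of 72 h (a higher number here means a weaker inhibitor, a lower number a stronger inhibitor), compound 1 gives 3400 nM, while compound 3 gives 1500 nM, which amounts to a 2.3-fold lower number from compound 1 to compound 3 (0.36 log units; beyond the scatter). Compound 2 `O=c1c(CSC(=S)N2CCOCC2)coc2cc(Cl)ccc12` is built on a different core; how its core differs from that of compound 1 is not broken down here. In this assay compound 2 gives 600 nM, the lowest of the three numbers, with its gaps to compound 3 and to compound 1 both beyond the scatter.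

Compound 4 `O=c1c(CSC(=S)N2CCCCC2)coc2cc(Cl)ccc12` has not been measured. It differs from compound 2 by piperidin-1-yl in place of morpholin-4-yl on a thiocarbonyl carbon, the same change that separates compound 1 from compound 3, made at the same place. Because that change gave a 2.3-fold lower number from compound 1 to compound 3 (0.36 log units; beyond the scatter), a step of about a 2.3-fold lower number from compound 2 to compound 4 (0.36 log units; beyond the scatter) is expected in this assay, resting on that single earlier pair. Compound 4 is therefore estimated at 260 nM, with a likely range from 120 nM to 600 nM.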

Compound 4, half-maximal inhibitory concentration: 240 nM
Compound 4: the middle estimate sits 1.1-fold (0.03 log units) above what was measured; measured number inside the range.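

In this assay, piperidin-1-yl in place of morpholin-4-yl on a thiocarbonyl carbon gave a 2.5-fold lower number from compound 2 to compound 4 (0.40 log units; beyond the scatter), and set beside the earlier step, the change carried over with no real difference in size: the same change on two cores in this assay, a 2.3-fold lower number (0.36 log units; beyond the scatter) from compound 1 to compound 3 and a 2.5-fold lower number (0.40 log units; beyond the scatter) from compound 2 to compound 4, 1.1-fold (0.04 log units) apart, within the scatter of two such steps. Within this series, then, the change gave a lower number on both cores, and the size of that step did not depend on which of these two cores carried it. Going by these compounds alone, this rests on only two pairs in a single cell assay, so it does not show that the step would hold on any further core or in another assay, and it gives no reason why piperidin-1-yl gives the lower number.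

The compounds shown leave open whether other amines on the thiocarbonyl carbon, such as pyrrolidine, piperazine or diethylamine, would also give lower numbers than morpholine. They also leave open whether the step would persist if the sulfur-containing chain joining this group to the core were lengthened by a further methylene.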